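This account rests on a few compounds, and the source may have more. Where it says the series, first, only, none or still open, it means among the compounds named here.

Compounds measured in a functional assay on the whole organism (strain Swiss albino) for inhibition, with Mus musculus as the target, in the writhing test, with stated times of 60 min and 15 min, at a dose of 100 mg/kg by the oral route; on this read-out lower numbers stand for less inhibition and higher numbers for more inhibition at the one dose given (going by the name of the read-out):
- compound 1, `CCCCNC(=O)CC1CCc2cc(OC)c(OC)cc21`, gives 39.4%
- compound 2, `COc1cc2c(cc1OC)C(CC(=O)NC(C)(C)C)CC2`, gives 41.8%
- compound 3, `COc1cc2c(cc1OC)C(CC(=O)NC1CCCC1)CC2`, gives 37%

Compound 3 holds the lowest of the three numbers, yet its gaps to the others, a number 2.4 percentage points lower from compound 1 to compound 3 (within the scatter) and a number 4.8 percentage points lower from compound 2 to compound 3 (within the scatter), both lie within the scatter, as does a number 2.4 percentage points higher from compound 1 to compound 2 (within the scatter). Compound 4, `COc1cc2c(cc1OC)C(CC(=O)NC1CCCCC1)CC2`, has not been measured. It differs from compound 3 by cyclohexyl in place of cyclopentyl on an amide-type nitrogen. The three steps that change the group on the amide-type nitrogen all stayed within the scatter, so no step beyond the scatter in this assay is expected for this change either. Compound 4 is therefore estimated at 39%, with a range from 29% to 49%, meaning an expected step of a number 2 percentage points higher from compound 3 to compound 4 (within the scatter).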

Compound 4, a percentage reported as inhibition, in the whole organism at one dose (the size of the read-out at that dose, not a potency): 44.7%
For compound 4 the middle estimate is 5.7 percentage points below the measured one, and the stated range covers the measured number.
By their numbers in this assay, from the lowest: compounds 3, 1, 2 and 4 (each within the scatter of the next).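

In this assay the new pair isolates ring size on the amide-type nitrogen, and that step, a number 7.7 percentage points higher from compound 3 to compound 4 (within the scatter), is the widest seen at this position without leaving the scatter. The other two steps, a number 2.9 percentage points higher from compound 2 to compound 4 (within the scatter) and a number 5.3 percentage points higher from compound 1 to compound 4 (within the scatter), likewise leave cyclohexyl level with tert-butyl and butyl. Nothing available bears on why this is so.

The compounds shown leave open whether any group on this nitrogen can move the number beyond the scatter. Going by these compounds, whether phenyl, benzyl or a butyl chain ending in an amine would do so remains unknown.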